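Diethylamino on the formylphenyl ring of compound 1

This account rests on a few compounds, and the source may have more. Where it says the series, first, only, none or still open, it means among the compounds named here.

Compound 1 `O=Cc1ccccc1OCc1cn(CCCOc2ccc3ccc(=O)oc3c2)nn1` is one of three compounds sharing a coumarin-linked triazole core measured in a functional assay on HT-29 cells (Homo sapiens) for cytotoxicity, read by MTT assay, with a stated time of 24 h; a higher number here means a weaker inhibitor, a lower number a stronger inhibitor. In this assay compound 1 gives 18900 nM, the second highest of the three numbers. Compound 2 `O=Cc1cccc(OCc2cn(CCCOc3ccc4ccc(=O)oc4c3)nn2)c1` gives 129000 nM, and the step of a 6.8-fold higher number from compound 1 to compound 2 (0.83 log units; beyond the scatter) accompanies the move of the formyl group. Compound 3 `COc1cccc(C=O)c1OCc1cn(CCCOc2ccc3ccc(=O)oc3c2)nn1` gives 13300 nM, and the step of a 1.4-fold lower number from compound 1 to compound 3 (0.15 log units; within the scatter) follows the methoxy addition, while a 9.7-fold lower number from compound 2 to compound 3 (0.99 log units; beyond the scatter) spans the larger rearrangement.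

Compound 4 `CCN(CC)c1ccc(C=O)c(OCc2cn(CCCOc3ccc4ccc(=O)oc4c3)nn2)c1` differs from compound 1 by diethylamino in place of hydrogen on an aromatic carbon, placed meta to a large group and para to the formyl group. The step most comparable is the ring substitution in a 1.4-fold lower number from compound 1 to compound 3 (0.15 log units; within the scatter), which stayed within the scatter; the formyl relocation in a 6.8-fold higher number from compound 1 to compound 2 (0.83 log units; beyond the scatter) does not bear on this change. A step no larger than the scatter is therefore expected, a 1.4-fold lower number from compound 1 to compound 4 (0.13 log units; within the scatter). Compound 4 is estimated at 14000 nM, with a range from 4500 nM to 45000 nM.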

Compound 4, half-maximal inhibitory concentration: 9030 nM
For compound 4 the middle estimate is 1.6-fold (0.19 log units) above the measured one; measured number inside the range.
By their numbers in this assay, from the lowest: compounds 4, 3 and 1 (each within the scatter of the next, the first and the last beyond it); then compound 2.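

Diethylamino in place of hydrogen on this aromatic carbon, para to a formyl group, gives a 2.1-fold lower number from compound 1 to compound 4 (0.32 log units; beyond the scatter) in this assay. The ring carbon therefore carries a substituent of 5 heavy atoms with no loss in this read-out, and the step reaches just past the scatter. The earlier ring substitution, methoxy, did not do so: it gave a 1.4-fold lower number from compound 1 to compound 3 (0.15 log units; within the scatter) and so showed no change that could be read. Nothing measured here explains why diethylamino gives this step.

Going by these compounds, what stays open is whether the step depends on the nitrogen or on the two ethyl chains, which a dimethylamino group, a pyrrolidine ring or a plain methoxy on this same carbon would help to separate. Also open, on these data alone, is whether the step would hold with a carboxylic acid in place of the formyl group.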